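Swapping the Chain End for a Phenyl Ring

The compounds below may be only part of what the source reports. "The series", "measured", "known", "first", "only" and "open" are said of these compounds alone.

Of the compounds shown here, two with a shared core have been measured in an assay on membranes from lung (Cavia porcellus) for binding affinity to cysteinyl leukotriene receptor (Homo sapiens); on this read-out lower numbers stand for stronger inhibition and higher numbers for weaker inhibition. Compound 1 `CCCCCCCCCCCCCCc1ccccc1C(SCCC(=O)O)SCCC(=O)O` gives 1250 nM. Compound 2 `CCCCCCCCCCCOc1ccccc1C(SCCC(=O)O)SCCC(=O)O` gives 287 nM, the lowest of the two numbers, and the distance to compound 1 is larger than the usual scatter, so compound 2 holds the stronger inhibition of the pair.

The next compound, compound 3 `O=C(O)CCSC(SCCC(=O)O)c1ccccc1OCCCCCCc1ccccc1`, differs from compound 2 in one place: phenyl in place of pentyl on a saturated chain carbon, six bonds along the chain from an oxygen on an aromatic ring. The rest of the structure, including the two acid-bearing chains on the core, is unchanged.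

Going by the values given here, no measured pair shows what this kind of exchange at the far end of the chain does in this assay, so the expected step rests on the close likeness of compound 2 and compound 3. The step from compound 2 to compound 3 is expected to be small, around a 1.2-fold higher number from compound 2 to compound 3 (0.09 log units; within the scatter), with no clear direction beyond the scatter. Compound 3 is therefore estimated at 350 nM, within a range from 120 nM to 1000 nM.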

Compound 3, inhibition constant: 11500 nM
Estimate against measurement, compound 3: 33-fold (1.52 log units) below; the whole stated range lies below it.
By their numbers in this assay, from the lowest: compound 2; then compound 1; then compound 3.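

The far end of the chain proves to be no neutral place in this assay: phenyl in place of pentyl gives a 40-fold higher number from compound 2 to compound 3 (1.60 log units; beyond the scatter). The exchange is modest when counted, since 5 heavy atoms of carbon leave, 6 heavy atoms of carbon enter, and neither group has hydrogen-bond donors or acceptors, yet the read-out moves far beyond the scatter, so a count of this kind alone does not foretell the size of a step at this position. The data at hand offer no independent measurement that could account for this step.

The compounds shown leave open whether the large step belongs to the phenyl ring itself or to the way the ring ends the chain, since the same difference can also be read as hexyl to benzyl or as octyl to 3-phenylpropyl. As far as these compounds go, a cyclohexyl group at the same place, or a longer chain carrying the phenyl ring further from the oxygen, would help separate these readings, and whether either one brings the number back towards that of compound 2 remains unknown.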